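The compounds below may be only part of what the source reports. "The series", "measured", "known", "first", "only" and "open" are said of these compounds alone.

Working notes on the series in a functional assay on K562 cells (Homo sapiens) for inhibition, read by trypan blue exclusion, with a stated time of 72 h; on this read-out lower numbers stand for stronger inhibition and higher numbers for weaker inhibition.

Of the compounds shown here, three have numbers so far. Compound 1 `Cn1c(=O)c(S(=O)(=O)c2ccccc2)cc2cnc(Nc3ccc4cc[nH]c4c3)nc21` gives 10000 nM in this assay. Compound 2 `Cn1c(=O)c(S(=O)(=O)c2ccc(F)cc2[N+](=O)[O-])cc2cnc(Nc3ccc4[nH]ccc4c3)nc21` gives 900 nM in this assay. Compound 3 `Cn1c(=O)c(S(=O)(=O)c2ccc(F)cc2)cc2cnc(Nc3ccc4occc4c3)nc21` gives 5000 nM in this assay. Compound 2 thus stands lowest of the three, with compound 3 nearest and compound 1 furthest, both gaps beyond the usual scatter; compound 2 is the strongest inhibitor among the measured set. Among the compounds with values here, no pair of measured compounds differs in one place only, so no single change can be read off directly.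

Compound 4 `Cn1c(=O)c(S(=O)(=O)c2ccc(C(=O)O)cc2)cc2cnc(Nc3ccc4[nH]ccc4c3)nc21` is not yet measured. It differs from compound 2 in one place: 4-carboxyphenyl in place of 4-fluoro-2-nitrophenyl on a sulfonyl sulfur. The measured set gives no direct guidance on this change. Only compound 2 carries the nitro group, and its lower number is the one that stands out, so a step upward, toward weaker inhibition, of moderate size is expected, a 3.3-fold higher number from compound 2 to compound 4 (0.52 log units; beyond the scatter). Compound 4 is expected to give about 3000 nM in this assay, with a range from 800 nM to 12000 nM.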

Compound 4, half-maximal inhibitory concentration: 5000 nM
Compound 4: the middle estimate sits 1.7-fold (0.22 log units) below what was measured, within the range that was stated.
By their numbers in this assay, from the lowest: compound 2; then compounds 3, 4 and 1 (each within the scatter of the next).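

Within the data shown here, the change on the sulfonyl sulfur is the first single change that can be read: in this assay 4-carboxyphenyl in place of 4-fluoro-2-nitrophenyl gives a 5.6-fold higher number from compound 2 to compound 4 (0.74 log units; beyond the scatter) and shows that the group held at this place matters to the read-out. The step is a combined one, removing the nitro group and the fluorine and bringing in the carboxylic acid together, so it cannot be assigned to any one of these groups. Nothing measured on these compounds accounts for the step.

On these data alone, whether the nitro group or the fluorine goes with the lower number of compound 2 remains open. Also open, as far as these compounds go, is where a 2-nitrophenyl group, or a phenyl group carrying a methyl ester or an amine, would fall at this place.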